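The compounds below may be only part of what the source reports. "The series", "measured", "known", "first", "only" and "open" are said of these compounds alone.

Working notes on the series. In a functional assay on HUVEC cells (Homo sapiens) for inhibition, using NADPH, with a stated time of 2 h (a higher number here means a weaker inhibitor, a lower number a stronger inhibitor), compound 1 `COc1ccc2[nH]c(COc3cccc(OCC4CCOCC4)c3)c(C)c(=O)c2c1` gives > 10000 nM, which is a limit of the assay and not a number. Among the measured compounds shown here, compound 2 `Cc1c(COc2cccc(OCC3CCOCC3)c2)[nH]c2ccc(Cl)cc2c1=O` gives 5 nM, the only true number so far. The comparison with compound 1 rests only on its limit, (the limit of > 10000 nM in this assay, at which 1 of the 2 values shown sits).

Compound 3 `Cc1c(COc2cccc(OCC3CCOCC3)c2)[nH]c2ccc(Br)cc2c1=O` is unmeasured and differs from compound 2 by bromo in place of chloro on an aromatic carbon of the six-membered aromatic ring of carbon only. For the measured compounds named here, one measured step bears on this same carbon: an at least 2000-fold lower number from compound 1 to compound 2 (3.30 log units; beyond the scatter), with chloro in place of methoxy. It is large and shows that this assay can respond strongly to a change at this place. However, it starts from a limit and involves a different exchange, and no bromo compound has been measured yet. The new exchange swaps one heavy atom for one, with no change in the counted donors, acceptors or charge. No shift beyond the scatter is therefore expected, and the estimated result is a 1.2-fold higher number from compound 2 to compound 3 (0.08 log units; within the scatter). The range is kept wide in view of the size of an at least 2000-fold lower number from compound 1 to compound 2 (3.30 log units; beyond the scatter). For compound 3 the expected value is 6 nM, with an estimated range of 2 nM to 25 nM.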

Compound 3, half-maximal inhibitory concentration: 23 nM
For compound 3 the middle estimate is 3.8-fold (0.58 log units) below the measured one; the measured number falls inside the stated range.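

The exchange of one halogen for another at this carbon is not silent in this assay: the step is a 4.6-fold higher number from compound 2 to compound 3 (0.66 log units; beyond the scatter), although chloro and bromo each count as one heavy atom, with no hydrogen-bond donors, no hydrogen-bond acceptors and no net charge. The earlier pair compared a halogen only with methoxy, so it could not show that this position also separates two halogens, with chloro giving the lower number of the two. Bromo in place of methoxy gives an at least 430-fold lower number from compound 1 to compound 3 (2.63 log units; beyond the scatter), so the large distance from methoxy is now seen with both halogens, but this step starts from the limit of compound 1 and its size can be read only as such: the limit of > 10000 nM in this assay, at which 1 of the 3 values shown sits.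

Going by these compounds, whether fluoro, iodo, methyl or a nitrile at this carbon would continue the difference between chloro and bromo stays open, since two halogens set no trend. Also open, on these data alone, is whether the step from chloro to bromo keeps its size when the rest of the shared core changes, for example with an amine or a carboxylic acid on the side chain.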